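Amide removal on the aryl-amine series: second instance

The source may hold more compounds than are shown below. What is called first, only, known or untested is meant among the compounds shown, and "the series" means these compounds.

Measured so far in a functional assay on L1210 cells (Mus musculus) for inhibition, read by cell counting, with a stated time of 2 days; on this read-out higher numbers stand for weaker inhibition and lower numbers for stronger inhibition:
- compound 1 `C=C(Br)C(=O)Nc1cccc(-c2cn3nc(-c4ccc(C)cc4)sc3n2)c1` gives 920 nM
- compound 2 `Cc1ccc(-c2nn3cc(-c4cccc(N)c4)nc3s2)cc1` gives 4800 nM
- compound 3 `C=C(Br)C(=O)Nc1cccc(-c2cn3nc(-c4ccc(Cl)cc4)sc3n2)c1` gives 1400 nM

Compound 4 `Nc1cccc(-c2cn3nc(-c4ccc(Cl)cc4)sc3n2)c1` is not yet measured in this assay. It differs from compound 3 by hydrogen in place of (1-bromoethenyl)carbonyl on a nitrogen on an aromatic ring. The same change has been measured once before, between compound 1 and compound 2, where it reads (hydrogen in place of (1-bromoethenyl)carbonyl on a nitrogen on an aromatic ring); that step was a 5.2-fold higher number from compound 1 to compound 2 (0.72 log units; beyond the scatter). The two place lines are word for word the same, so this is the same change made on a different core. The two cores differ by chloro in place of methyl on an aromatic carbon, a step of a 1.5-fold higher number from compound 1 to compound 3 (0.18 log units; within the scatter).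

Among the compounds with values here, with only one earlier instance, and the cores close to each other in this assay, the expectation for compound 4 is a step of about the same size as before, namely a 5.0-fold higher number from compound 3 to compound 4 (0.70 log units; beyond the scatter), because of the earlier step of a 5.2-fold higher number from compound 1 to compound 2 (0.72 log units; beyond the scatter) and the value of compound 3, 1400 nM. Compound 4 is therefore estimated at 7000 nM, with the likely range 3000 nM to 17000 nM.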

Compound 4, half-maximal inhibitory concentration: >= 250000 nM
Compound 4: no number, only a limit (the forecaster's own chance of this, stated with the estimate: 5%); middle value at least 35-fold (1.55 log units) away from the limit.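

In this assay compound 4 gives >= 250000 nM, which is a limit of the assay and not a number. With chloro on the aromatic carbon, hydrogen in place of (1-bromoethenyl)carbonyl gives an at least 170-fold higher number from compound 3 to compound 4 (2.25 log units; beyond the scatter), and the size of the step does not carry over from the methyl-bearing pair: the same change on two cores in this assay, a 5.2-fold higher number (0.72 log units; beyond the scatter) from compound 1 to compound 2 and an at least 170-fold higher number (2.25 log units; beyond the scatter) from compound 3 to compound 4, at least 34-fold (1.53 log units) apart, beyond the scatter of two such steps Seen from the other side, chloro in place of methyl gives an at least 52-fold higher number from compound 2 to compound 4 (1.71 log units; beyond the scatter) when the nitrogen carries only hydrogen, so the two changes do not act independently in these four compounds, although the data show neither why this is so nor whether it holds beyond them: the same change on two cores in this assay, a 1.5-fold higher number (0.18 log units; within the scatter) from compound 1 to compound 3 and an at least 52-fold higher number (1.71 log units; beyond the scatter) from compound 2 to compound 4, at least 34-fold (1.53 log units) apart, beyond the scatter of two such steps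

The compounds shown leave open whether the large step is particular to chloro or also appears with fluoro or methoxy on that aromatic carbon. They also leave open whether an acetyl group on the nitrogen would read like the (1-bromoethenyl)carbonyl group or like the free amine.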